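This account rests on a few compounds, and the source may have more. Where it says the series, first, only, none or still open, it means among the compounds named here.

Measured so far:

compound 1 `COC(=O)c1sc2cc(C#Cc3ccccn3)cnc2c1N`: in a functional assay on A375-C5 cells (Homo sapiens) for inhibition, read by sulforhodamine B assay, with a stated time of 48 h (on this read-out lower numbers stand for stronger inhibition of growth and higher numbers for weaker inhibition of growth), compound 1 gives 13900 nM.
compound 2 `COC(=O)c1sc2cc(C#Cc3ccccc3F)cnc2c1N`: in this assay compound 2 reaches only the limit of the assay, > 150000 nM.

Going by the values given here, compound 1 holds the only real number in the set; the other entry is a limit (the limit of > 150000 nM in this assay, at which 1 of the 2 values shown sits), so its standing is simply that of the one compound with a measurable result. The single step on record, an at least 10-fold higher number from compound 1 to compound 2 (1.03 log units; beyond the scatter), ends at that limit and is therefore at least as large as shown.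

The step now followed goes from compound 1 to compound 3 `COC(=O)c1sc2cc(C#Cc3ccccc3N)cnc2c1N`: 2-aminophenyl in place of pyridin-2-yl on a triple-bonded carbon. It bears on the measured step in that the pyridin-2-yl ring leaves in both cases and a ring of carbon only enters; the entering group here carries an amino group in place of the fluorine. Given an at least 10-fold higher number from compound 1 to compound 2 (1.03 log units; beyond the scatter), the swap of the pyridin-2-yl ring for a carbon-only ring has already cost the series its measurable activity once, so a step upward in this assay beyond the scatter is expected for compound 3, with the amino group the sole reason to expect it to stay short of the limit. Compound 3 is estimated at 45000 nM (range 12000 nM to 150000 nM), that is an expected step of a 3.2-fold higher number from compound 1 to compound 3 (0.51 log units; beyond the scatter).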

Compound 3, concentration for 50% growth inhibition: 3100 nM
Beside the measured number, compound 3's estimate is 15-fold (1.16 log units) above it, outside the stated range (below it).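

In this assay, a ring of carbon only on the triple-bonded carbon does not by itself end the activity: 2-aminophenyl in place of pyridin-2-yl gives a 4.5-fold lower number from compound 1 to compound 3 (0.65 log units; beyond the scatter), so among the compounds shown the pyridin-2-yl ring is not required at this position. What sits on the carbon-only ring matters as well, since amino in place of fluoro on an aromatic carbon gives an at least 48-fold lower number from compound 2 to compound 3 (1.68 log units; beyond the scatter), which means the result of the earlier step cannot be read as a general penalty for losing the pyridin-2-yl ring. The true size of this second step stays unknown, as compound 2 stands at a limit and not at a number: the limit of > 150000 nM in this assay, at which 1 of the 3 values shown sits.

The compounds shown leave open whether the result belongs to the amino group itself or would also hold for a hydroxyl, a dimethylamino or an acetamido group on the same aromatic carbon. They also leave open where an unsubstituted phenyl would fall, and whether 2-aminophenyl keeps its effect when the methyl ester of the shared core gives way to a carboxylic acid or a primary amide.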